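A few compounds are considered here, and "the series" means these few. Any claim that something is new, unique, unknown or untested is made for them only; others in the source may bear on it.

Four compounds that share a core were compared in an ADME assay (liver) for metabolic stability, with Liver microsome (Rattus norvegicus) as the target, using microsomes; a lower number here means slower removal, a higher number faster removal of the compound. Compound 1 `c1ccc(CNc2nnc(-c3c[nH]c4ncccc34)o2)cc1` gives 40 mL.min-1.g-1 in this assay, and compound 2 `Fc1ccccc1CNc1nnc(-c2c[nH]c3ncccc23)o1` gives 46 mL.min-1.g-1. Between them lies a single change, (fluoro in place of hydrogen on an aromatic carbon), and it produced a 1.2-fold higher number from compound 1 to compound 2 (0.06 log units; within the scatter). Compound 3 `Fc1ncccc1[C@H](Nc1nnc(-c2c[nH]c3ncccc23)o1)C1CC1` gives 80 mL.min-1.g-1; the difference between its core and the core of compound 1 is not broken down here. Compound 4 `Fc1cnc2[nH]cc(-c3nnc(N[C@@H](c4cccnc4F)C4CC4)o3)c2c1`, still unmeasured, differs from compound 3 by fluoro in place of hydrogen on an aromatic carbon. This is the same kind of change as that from compound 1 to compound 2, but not the same: there the fluoro entered a six-membered aromatic ring of carbon only, ortho to a large group, whereas here it enters a six-membered aromatic ring with one nitrogen, part of a fused system, meta and para to a fused ring. Because the earlier step was a 1.2-fold higher number from compound 1 to compound 2 (0.06 log units; within the scatter), a step of similar size, no change at the digits printed from compound 3 to compound 4 (within the scatter), is expected. Compound 4 is therefore estimated at 80 mL.min-1.g-1, likely between 45 mL.min-1.g-1 and 140 mL.min-1.g-1.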

Compound 4, intrinsic clearance in microsomes: 20 mL.min-1.g-1
Compound 4: middle estimate off by 4.0-fold (0.60 log units), on the high side; measured number outside the range, below it.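

In this assay, fluoro in place of hydrogen on the ring with one nitrogen gave a 4.0-fold lower number from compound 3 to compound 4 (0.60 log units; beyond the scatter), so this change did not carry over with the same size from one core to the other: the same change on two cores in this assay, a 1.2-fold higher number (0.06 log units; within the scatter) from compound 1 to compound 2 and a 4.0-fold lower number (0.60 log units; beyond the scatter) from compound 3 to compound 4, 4.6-fold (0.66 log units) apart, beyond the scatter of two such steps. The two steps also place the fluoro on different rings, one of carbon only and one with one nitrogen, so they cannot tell whether the ring, the position or the rest of the molecule sets the size of the step. Two steps make no rule for other cores, and they do not explain why the number fell.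

On these data alone, it remains open whether chloro, methyl or a nitrile on that same aromatic carbon of compound 3 would also lower the number. As far as these compounds go, it also remains open whether fluoro on that same aromatic carbon of compound 1 would give a similar step.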